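This account rests on a few compounds, and the source may have more. Where it says the series, first, only, none or still open, it means among the compounds named here.

Compound 1, with structure `C#CC[C@H]1C[C@H](n2cccc2C(=O)C(F)(F)F)C(=O)O1`, gives 97800 nM in an ADME assay on N2a cells (Mus musculus) for cytotoxicity, read by MTT assay; on this read-out lower numbers stand for stronger inhibition and higher numbers for weaker inhibition. Compound 2, with structure `CC(=O)c1cccn1[C@H]1C[C@@H](CC#Cc2ccc([N+](=O)[O-])cc2)OC1=O`, reaches only a limit of this assay, namely > 100000 nM. On the numbers shown, compound 2 therefore stands at the limit of > 100000 nM in this assay, at which 1 of the 2 values shown sits, and no number for it is available. Compound 3, with structure `CC(=O)c1cccn1[C@H]1C[C@H](CC#Cc2ccc([N+](=O)[O-])cc2)OC1=O`, is the compound that follows. Relative to compound 2, (the two compounds have the same atoms and bonds and differ only in configuration as drawn: 1 of 2 stereo elements differ; a stereocentre at a saturated ring carbon is drawn R in compound 2 and S in compound 3). No measured step between two such configurations exists among the compounds shown, so the size of the change has no precedent here. A shift in configuration at one ring carbon is expected to leave compound 3 close to compound 2, with no step beyond the usual scatter, and the step of a number no higher from compound 2 to compound 3 (the limit leaves the size open) is the expected outcome. Compound 3 is accordingly estimated at 100000 nM, within a range of 50000 nM to 200000 nM, with a fair chance that this assay again reports only a limit.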

Compound 3, half-maximal inhibitory concentration: > 100000 nM
Compound 3 ended at the assay's limit; the forecaster's own chance of this, stated with the estimate: 65%; the middle value sits exactly at the limit.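

Compound 2 and compound 3 both end at a limit of this assay rather than at a number, so the step between these two configurations cannot be read: the limit of > 100000 nM in this assay, at which 2 of the 3 values shown sit. The compounds shown leave open whether the configuration at this saturated ring carbon alters the read-out in this assay at all.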